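The source may hold more compounds than are shown below. What is called first, only, known or untested is meant among the compounds shown, and "the series" means these compounds.

Of the compounds shown here, three built on one shared core have been tested in an ADME assay on HEK293 cells (Homo sapiens) for inhibition, read by MTT assay, with stated times of 18 h and 4 h; a lower number here means a stronger inhibitor, a higher number a weaker inhibitor. Compound 1 `CCCCCCCCOP(=O)(O)OCCSC(=S)N1CCCC1` gives 28300 nM. Compound 2 `CCCCCCCCOP(=O)(O)OCCSC(=S)N1CCCCCC1` reaches only a limit of the assay, > 100000 nM. Compound 3 `CCCCCCOP(=O)(O)OCCSC(=S)N1CCCCCC1` gives 70500 nM. The cores of compound 2 and compound 3 differ by hydrogen in place of ethyl on a saturated chain carbon, six bonds along the chain from an oxygen on an unsaturated carbon, which made a step of an at least 1.4-fold lower number from compound 2 to compound 3 (0.15 log units; that floor lies within the scatter).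

From compound 2 to compound 1 the change is pyrrolidin-1-yl in place of azepan-1-yl on a thiocarbonyl carbon, and it made a step of an at least 3.5-fold lower number from compound 2 to compound 1 (0.54 log units; beyond the scatter); that step is a floor because compound 2 sits at the limit of > 100000 nM in this assay, at which 1 of the 3 values shown sits. Compound 4 `CCCCCCOP(=O)(O)OCCSC(=S)N1CCCC1` carries the same change, (pyrrolidin-1-yl in place of azepan-1-yl on a thiocarbonyl carbon), on the core of compound 3. Compound 4 is expected to show a step of a 3.5-fold lower number from compound 3 to compound 4 (0.55 log units; beyond the scatter), resting on an at least 3.5-fold lower number from compound 2 to compound 1 (0.54 log units; beyond the scatter). Compound 4 is thus estimated at 20000 nM, between 8000 nM and 50000 nM.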

Compound 4, half-maximal inhibitory concentration: > 100000 nM
Compound 4 was reported as a limit; the forecaster's own chance of this, stated with the estimate: 5%; middle value at least 5.0-fold (0.69 log units) away from the limit.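

In this assay compound 4 gives > 100000 nM, which is a limit of the assay and not a number. Pyrrolidin-1-yl in place of azepan-1-yl therefore does not carry over unchanged from one core to the other, giving an at least 1.4-fold higher number from compound 3 to compound 4 (0.15 log units; that floor lies within the scatter) instead of the lower number seen on the other core: the same change on two cores in this assay, an at least 3.5-fold lower number (0.54 log units; beyond the scatter) from compound 2 to compound 1 and an at least 1.4-fold higher number (0.15 log units; that floor lies within the scatter) from compound 3 to compound 4, at least 5.0-fold (0.70 log units) apart, beyond the scatter of two such steps Hydrogen in place of ethyl also depends on its core, giving an at least 3.5-fold higher number from compound 1 to compound 4 (0.54 log units; beyond the scatter), but these steps are only floors, so their true sizes remain unknown: the same change on two cores in this assay, an at least 1.4-fold lower number (0.15 log units; that floor lies within the scatter) from compound 2 to compound 3 and an at least 3.5-fold higher number (0.54 log units; beyond the scatter) from compound 1 to compound 4, at least 5.0-fold (0.70 log units) apart, beyond the scatter of two such steps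

The compounds shown leave open whether a piperidin-1-yl group would behave like either of these rings. They also leave open how a longer chain would act on either ring.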